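Bromine on the benzyl group of chalcone-triazole hybrids

The source may hold more compounds than are shown below. What is called first, only, known or untested is meant among the compounds shown, and "the series" means these compounds.

Compound 1 `COc1ccc(C(=O)/C=C/c2ccc(OCc3cn(Cc4ccccc4)nn3)cc2)cc1` and compound 2 `COc1ccc(C(=O)/C=C/c2ccc(OCc3cn(Cc4ccc(Br)cc4)nn3)cc2)cc1` share a core and differ by bromo in place of hydrogen on an aromatic carbon. In a functional assay on MIA PaCa-2 cells (Homo sapiens) for inhibition, read by MTT assay, with a stated time of 48 h, tested at 10 uM (on this read-out lower numbers stand for less inhibition of growth and higher numbers for more inhibition of growth at the one concentration tested), compound 1 gives 68%, and compound 2 gives 56%; the change is a number 12 percentage points lower from compound 1 to compound 2 (beyond the scatter). Compound 3 `O=C(/C=C/c1ccc(OCc2cn(Cc3ccccc3)nn2)cc1)c1ccc([N+](=O)[O-])cc1` differs from compound 1 by nitro in place of methoxy on an aromatic carbon, and in this assay compound 3 gives "not active" (no number reported), with no number. Compound 4 `O=C(/C=C/c1ccc(OCc2cn(Cc3ccccc3Br)nn2)cc1)c1ccc([N+](=O)[O-])cc1` differs from compound 3 by bromo in place of hydrogen on an aromatic carbon. This is the same kind of change as from compound 1 to compound 2, not the same: there the bromo sits para to a large group, here ortho to a large group. Since compound 3 gave no measurable inhibition, and the comparable change lowered the number from compound 1 to compound 2, compound 4 is expected to stay weak, estimated around 10%.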

Compound 4, percent growth inhibition at one concentration: 34%
Compound 4: middle estimate off by 24 percentage points, on the low side; measured number above the stated range.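

In this assay, within the data shown here, compound 3 has no number, so no step from compound 3 to compound 4 can be read. No supporting data bear on this result. Open remains whether bromo in compound 4 changes growth inhibition differently when ortho to a large group.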